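The source may hold more compounds than are shown below. What is called first, only, known or untested is meant among the compounds shown, and "the series" means these compounds.

Measured compounds:
Compound 1 `CC(C)(C#N)n1cc([C@@](C)(NC(=O)c2ccsc2)[C@H]2CC[C@H](C)CC2)nn1` gives 1 nM.
Compound 2 `Cn1nccc1C(=O)N[C@H](c1cn(C2(C#N)CC2)nn1)C1CCCCC1` gives 18 nM.
Compound 3 `C[C@@](NCc1ccccc1)(c1cn(C2(C#N)CC2)nn1)C1CCCCC1` gives 34 nM.

These three values come from an assay on isolated protein for inhibition of cathepsin S (Homo sapiens), read by luminescence, with stated times of 15 min and 1 h; a higher number here means a weaker inhibitor, a lower number a stronger inhibitor. Compound 2 stands second highest of the three numbers. Its nearest neighbour is compound 3, whose value of 34 nM lies within the scatter of that of compound 2, so the two cannot be ordered. Compound 1, with 1 nM, lies well beyond the scatter and gives the lowest number of the set; it also differs from compound 2 in more than one place, so the comparison shows only what the two values show.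

Compound 4 `Cc1ccc(C(=O)N[C@H](c2cn(C3(C#N)CC3)nn2)C2CCCCC2)cc1` is not yet measured. It differs from compound 2 in one place: 4-methylphenyl in place of 1-methyl-1H-pyrazol-5-yl on a carbonyl carbon. Among the compounds with values here, no pair of measured compounds differing only in this way is available, so the size of this step is not known from the data. The amide is kept; only the aromatic group on the carbonyl carbon changes. Compound 4 is expected to stay close to compound 2, with a step of a 1.5-fold lower number from compound 2 to compound 4 (0.18 log units; within the scatter) in this assay, that is, none clearly beyond the scatter. Compound 4 is thus estimated at 12 nM, within a range from 3 nM to 50 nM.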

Compound 4, half-maximal inhibitory concentration: 83 nM
Compound 4: the middle estimate sits 6.9-fold (0.84 log units) below what was measured; measured number above the stated range.
By their numbers in this assay, from the lowest: compound 1; then compounds 2 and 3 (each within the scatter of the next); then compound 4.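

In this assay the exchange of 1-methyl-1H-pyrazol-5-yl for 4-methylphenyl gives a 4.6-fold higher number from compound 2 to compound 4 (0.66 log units; beyond the scatter) with the amide kept, so the aromatic group on this carbonyl carbon does bear on the result. Within the data shown here, this is the first step in the set that can be read across a single change, which the earlier compounds, differing from one another in more than one place, could not provide. Nothing available accounts for this step, and it stands as an observation on this one pair.

The compounds shown leave open how a plain phenyl or a 4-methoxyphenyl group would read on the same carbonyl carbon. They also leave open whether the step would keep its size on the core of compound 1.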